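Replacing the pendant group on a shared core

A few compounds are considered here, and "the series" means these few. Any claim that something is new, unique, unknown or untested is made for them only; others in the source may bear on it.

Measured so far:
compound 1 `CCOC(=O)c1c(-c2ccccc2)nn(-c2ccccc2)c1COc1cc(OC)c(C=O)c(OC)c1` gives 40 ug/mL
compound 2 `CCOC(=O)c1c(-c2ccccc2)nn(-c2ccccc2)c1Cn1c(S)nc2ccccc21` gives 40 ug/mL

In an assay for inhibition of Alpha amylase (Homo sapiens), with a stated time of 30 min (on this read-out higher numbers stand for weaker inhibition and lower numbers for stronger inhibition), compound 2 gives 40 ug/mL. Compound 1, which carries a different group on the same saturated chain carbon, gives 40 ug/mL in this assay, so compound 2 stands level with compound 1 at the digits shown, and the two values lie within the scatter of repeated measurements. The pendant group thus changed from compound 1 to compound 2 without a visible effect on the read-out.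

Compound 3 `CCOC(=O)c1c(-c2ccccc2)nn(-c2ccccc2)c1COCc1ccccc1` has not yet been measured. It differs from compound 2 as follows: a group of 8 heavy atoms (7 carbon, 1 oxygen; one six-membered aromatic ring of carbon only) in place of a group of 10 heavy atoms (7 carbon, 2 nitrogen, 1 sulfur; one five-membered aromatic ring with 2 hetero atoms, one six-membered aromatic ring of carbon only), on a saturated chain carbon bound to an aromatic carbon. Within the data shown here, no step between two measured compounds covers this exact change, so the expectation rests on the observation that compounds 1 and 2 show the same value despite different groups at this place. The step of a 1.1-fold higher number from compound 2 to compound 3 (0.05 log units; within the scatter) is expected to stay within the scatter, with no clear direction. Compound 3 is therefore estimated to give about 45 ug/mL in this assay, with a range from 20 ug/mL to 120 ug/mL.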

Compound 3, half-maximal inhibitory concentration: 45 ug/mL
Compound 3: the middle estimate sits on the measured number at the digits printed; low and high end bracket the measured number.
By their numbers in this assay, from the lowest: compounds 1, 2 and 3 (each within the scatter of the next).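

In this assay, benzyloxy on the saturated chain carbon, with 0 hydrogen-bond donors and 1 hydrogen-bond acceptor, takes the place of a two-ring group with 1 hydrogen-bond donor and 3 hydrogen-bond acceptors, and the result is a 1.1-fold higher number from compound 2 to compound 3 (0.05 log units; within the scatter), so this difference in donors and acceptors leaves no visible mark on the read-out. The same holds for a much simpler group on the oxygen: a plain six-membered carbon ring with its 7 carbon atoms stands in place of a group of 12 heavy atoms, giving a 1.1-fold higher number from compound 1 to compound 3 (0.05 log units; within the scatter), which shows that the extra oxygen-bearing substituents of the larger group are not needed to reach this level. No measurement here explains why such different groups read alike.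

Going by these compounds, all three pendant groups contain an aromatic ring and give values within the scatter of one another, so it remains open whether this place can move the read-out at all. An amine, a carboxylic acid or a single hydroxyl on the saturated chain carbon, none of which brings an aromatic ring, would test that question.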